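Halomethyl exchange on the saturated ring carbon

The source may hold more compounds than are shown below. What is called first, only, known or untested is meant among the compounds shown, and "the series" means these compounds.

The series is read in a functional assay on Lu1 cells (Homo sapiens) for cytotoxicity; on this read-out lower numbers stand for an effect already at smaller amounts and higher numbers for an effect only at larger amounts of compound. Compound 2 `CCC[C@@H](OC(C)=O)C1=C(Br)[C@@](CI)(OC)OC1=O` gives only a limit in this assay, > 20 ug/mL. Compound 1 `CCC[C@@H](OC(C)=O)C1=C(Br)[C@@](C)(OC)OC1=O` likewise reaches only a limit in this assay, > 20 ug/mL. The step that the two limits leave unreadable from compound 1 to compound 2 is therefore not readable, as shown by the limit of > 20 ug/mL in this assay, at which 2 of the 3 values shown sit. Going by the values given here, no single-place step links compound 2 to compound 3; in this assay compound 3 `CCC[C@@H](O)C1=C(Br)C(=C(Br)Br)OC1=O` gives 1.7 ug/mL. Compound 4 `CCC[C@@H](OC(C)=O)C1=C(Br)[C@](OC)(C(Br)Br)OC1=O` carries the change (dibromomethyl in place of iodomethyl on a saturated ring carbon). Among the compounds with values here, no measured step bears on this change beyond the unreadable one, so no step beyond the scatter is expected. Compound 4 is expected to remain near the limit, with a number no higher from compound 2 to compound 4 (the limit leaves the size open). Compound 4 is estimated at 20 ug/mL, between 7 ug/mL and 60 ug/mL.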

Compound 4, concentration for half-maximal effect: > 20 ug/mL
Compound 4 ended at the assay's limit; the forecaster's own chance of this, stated with the estimate: 60%; the middle value sits exactly at the limit.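

In this assay compound 4 also gives only a limit, > 20 ug/mL. Its steps from compound 1 and compound 2 therefore cannot be read: the limit of > 20 ug/mL in this assay, at which 3 of the 4 values shown sit.

The compounds shown leave open whether exchanging the group on the saturated ring carbon changes the read-out at all.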